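This account rests on a few compounds, and the source may have more. Where it says the series, first, only, none or still open, it means among the compounds named here.

Compound 1, with the structure `Oc1ccc(CNc2ccc(O)c(O)c2)cc1O`, is a weak inhibitor in an assay on liver for inhibition of arginase-1 (Bos taurus), with a stated time of 60 min (a lower number here means a stronger inhibitor, a higher number a weaker inhibitor), where compound 1 gives 76000 nM. Compound 2, with the structure `Oc1cccc(NCc2ccc(O)c(O)c2)c1`, gives 83000 nM in this assay. The two numbers sit close together: the step of a 1.1-fold higher number from compound 1 to compound 2 (0.04 log units; within the scatter) lies within the scatter, so compound 1 shows the lower of the two numbers without standing apart from compound 2.

Compound 3, with the structure `O=C(O)c1cc(NCc2ccc(O)c(O)c2)ccc1O`, has not yet been measured in this assay. It differs from compound 1 in one place: carboxy in place of hydroxy on an aromatic carbon, the change sitting ortho to a hydroxy group and meta to a large group on the shared core.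

For the measured compounds named here, only one measured step bears on this change, and it concerns the same kind of position: removing a hydroxy group gave the step of a 1.1-fold higher number from compound 1 to compound 2 (0.04 log units; within the scatter), which stayed within the scatter. A swap of that hydroxy for a carboxy is therefore expected to move the number little, with the step of a 1.1-fold lower number from compound 1 to compound 3 (0.04 log units; within the scatter) expected to remain within the scatter. Compound 3 is estimated to give 70000 nM in this assay, within a range from 20000 nM to 250000 nM.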

Compound 3, half-maximal inhibitory concentration: 187000 nM
Compound 3: the middle estimate sits 2.7-fold (0.43 log units) below what was measured; measured number inside the range.
By their numbers in this assay, from the lowest: compounds 1 and 2 (each within the scatter of the next); then compound 3.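

The carboxy swap does something the earlier step did not: in this assay, the move a 2.5-fold higher number from compound 1 to compound 3 (0.39 log units; beyond the scatter) makes for a weaker inhibitor, if only modestly, whereas the loss of a hydroxy group in a 1.1-fold higher number from compound 1 to compound 2 (0.04 log units; within the scatter) stayed within the scatter. So a change to a hydroxy group on this part of the shared core is not always without effect, and the outcome depends on what takes its place and where. The counts of hydrogen-bond donors and acceptors are the same for the hydroxy that leaves and the carboxy that enters, so those counts alone do not predict this step, and the heavy-atom count rises from one atom to three; nothing among the data shown accounts for the shift.

The compounds shown leave open whether the carboxylic acid itself matters or whether any larger group in this place would do the same, which a methyl ester, a primary amide or a methoxy group there could help to separate. They also leave open what a plain hydrogen would give at this exact place, and whether a carboxy on the other ring would behave alike.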